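Removal of the methoxy group in a glucose-6-phosphatase series

This account rests on a few compounds, and the source may have more. Where it says the series, first, only, none or still open, it means among the compounds named here.

Compound 1 `CCOC(=O)C1(O)CC(c2ccc(OC)cc2)C2=C(CC(C)(C)CC2=O)O1` was tested in an assay on isolated protein for inhibition of glucose-6-phosphatase catalytic subunit 1 (Homo sapiens), read by inositol phosphate accumulation, with a stated time of 30 min, tested at 100 uM (on this read-out lower numbers stand for less inhibition and higher numbers for more inhibition at the one concentration tested (going by the name of the read-out)), and is recorded only as "not active" (no number reported); no single number stands against it, so its place on the read-out is known only as the absence of a measurable effect. Compound 2 `CC1(C)CC(=O)C2=C(C1)NC(c1ccccc1)=CC2c1ccc(Cl)cc1`, which shares the core but carries different substituents, gives 7.16% in this assay, a value that lies well within the usual scatter of the zero point. Compound 3 `CCOC(=O)C1(O)CC(c2ccccc2)C2=C(CC(C)(C)CC2=O)O1` has not yet been measured. It differs from compound 1 in one place: hydrogen in place of methoxy on an aromatic carbon. Within the data shown here, no step between measured compounds is available for this change, so nothing in the data says whether the change in this assay moves the read-out up, down, or not at all. Given that compound 1 showed no activity and that compound 2 also sits near zero, the expectation for compound 3 in this assay is a small value, estimated at 5% with a range from -5% to 15%, and it may well again be reported only as inactive.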

Compound 3, a percentage reported as inhibition, at one concentration (the size of the read-out at that concentration, not a potency): "not active" (no number reported)
For compound 3 the study gives words and no number, and the estimate cannot be compared.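

In this assay compound 1 gives "not active" (no number reported) and compound 3 gives "not active" (no number reported), so no step can be read between them. No evidence bears on this result. The compounds shown leave open whether going from 4-methoxyphenyl to phenyl changes the read-out in this assay at all.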